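The compounds below may be only part of what the source reports. "The series", "measured", "known", "first", "only" and "open" are said of these compounds alone.

Of the compounds shown here, three sharing one core have been measured in an ADME assay on a cell-free system (plasma, Mus musculus, strain CD-1) for protein binding. Compound 2 `CCCS(=O)(=O)Nc1ccc(F)c(C(=O)Nc2cnc3[nH]ncc3c2)c1F` gives 87.1%, the lowest value of the three and therefore the largest free fraction. Compound 3 `CCCS(=O)(=O)Nc1ccc(Cl)c(C(=O)Nc2cnc3[nH]ncc3c2)c1F` gives 97.1%, and compound 1 `CCCS(=O)(=O)Nc1ccc(Cl)c(C(=O)Nc2cnc3[nH]nc(OC)c3c2)c1F` gives 99.1%.

Compound 4 `CCCS(=O)(=O)Nc1ccc(F)c(C(=O)Nc2cnc3[nH]nc(C)c3c2)c1F` departs from compound 2 by a single change, methyl in place of hydrogen on an aromatic carbon. Within the data shown here, no measured compound carries this methyl, so the evidence is indirect. The closest guide is a 3.2-fold higher unbound fraction from compound 1 to compound 3 (0.51 log units; beyond the scatter), where hydrogen replaces methoxy on the same carbon. Read in reverse, placing a group there went with less free compound. The guide is imperfect: methoxy is not methyl, and compound 1 and compound 3 carry chloro where compound 2 and compound 4 carry fluoro. The other measured step, a 4.4-fold lower unbound fraction from compound 2 to compound 3 (0.65 log units; beyond the scatter), is that chloro in place of fluoro. It lies elsewhere on the molecule and shows only how far one small swap can move this assay in these compounds.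

A modest fall in the free fraction is therefore expected, somewhat smaller than the methoxy step. The estimate is a 2.2-fold lower unbound fraction from compound 2 to compound 4 (0.33 log units; beyond the scatter). For compound 4 the expected value is 94%, with an estimated range from 89% to 97.5%.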

Compound 4, plasma protein binding: 89.9%
Beside the measured number, compound 4's estimate is 1.7-fold (0.23 log units) (unbound fraction) below it; the measured number falls inside the stated range.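

In this assay, adding a methyl to the carbon of the five-membered aromatic ring gives a 1.3-fold lower unbound fraction from compound 2 to compound 4 (0.11 log units; within the scatter), so compound 2 and compound 4 cannot be told apart in this measurement. Among these compounds, this is the first view of this carbon in the fluoro compounds, and it shows that placing a small group there need not shift binding beyond normal measurement noise, whereas the only earlier step at this carbon, a 3.2-fold higher unbound fraction from compound 1 to compound 3 (0.51 log units; beyond the scatter), involved a methoxy group on chloro compounds and did lie beyond the scatter. No supporting evidence is available to explain the result, and the methoxy and methyl steps differ both in the group and in the halogen elsewhere on the molecule.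

The compounds shown leave open whether methyl would also make no readable difference alongside chloro, and whether methoxy alongside fluoro would repeat the shift seen alongside chloro. They also do not show how an amine, a carboxylic acid or a longer chain on this same carbon would affect plasma protein binding.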